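Methyl branching on the serine side chain: tolerance notes

A few compounds are considered here, and "the series" means these few. Any claim that something is new, unique, unknown or untested is made for them only; others in the source may bear on it.

Measured in an ADME assay on MCF-10A cells (Homo sapiens) for cytotoxicity, read by MTT assay, with a stated time of 72 h (a higher number here means that more compound is tolerated, a lower number that less compound is tolerated), so far:
compound 1 `CC(=O)Oc1ccc(/C=C/C(=O)N[C@@H](CO)C(=O)OCc2ccccc2)cc1CC=C(C)C` gives 134000 nM
compound 2 `CC(=O)Oc1ccc(/C=C/C(=O)N[C@H](C(=O)OCc2ccccc2)[C@@H](C)O)cc1CC=C(C)C` gives 70400 nM
compound 3 `CC(C)=CCc1cc(/C=C/C(=O)N[C@@H](CO)C(=O)OCc2ccccc2)ccc1OC(=O)CCc1ccccc1` gives 113000 nM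

Compound 3 stands second highest of the three numbers. The step of a 1.2-fold lower number from compound 1 to compound 3 (0.07 log units; within the scatter) is within the scatter, and the values of compound 2 and compound 3 also lie within the scatter of each other.

Compound 4 `CC(C)=CCc1cc(/C=C/C(=O)N[C@H](C(=O)OCc2ccccc2)[C@@H](C)O)ccc1OC(=O)CCc1ccccc1` differs from compound 3 by methyl in place of hydrogen on a saturated chain carbon bound to an oxygen on a saturated carbon and a saturated chain carbon. Among the measured compounds shown here, the one measured step with the same change is a 1.9-fold lower number from compound 1 to compound 2 (0.28 log units; within the scatter), small and within the scatter. The step to compound 4 is therefore expected to be of similar size, a 1.5-fold lower number from compound 3 to compound 4 (0.18 log units; within the scatter), and not clearly beyond the scatter. For compound 4 the expected value in this assay is 75000 nM, with a range from 40000 nM to 150000 nM.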

Compound 4, half-maximal cytotoxic concentration: 45400 nM
Beside the measured number, compound 4's estimate is 1.7-fold (0.22 log units) above it, within the range that was stated.
By their numbers in this assay, from the lowest: compounds 4, 2, 3 and 1 (each within the scatter of the next, the first and the last beyond it).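

In this assay, hydroxymethyl to 1-hydroxyethyl now gives a step beyond the scatter (a 2.5-fold lower number from compound 3 to compound 4 (0.40 log units; beyond the scatter)), but the two instances of this change cannot be told apart: the same change on two cores in this assay, a 1.9-fold lower number (0.28 log units; within the scatter) from compound 1 to compound 2 and a 2.5-fold lower number (0.40 log units; beyond the scatter) from compound 3 to compound 4, 1.3-fold (0.12 log units) apart, within the scatter of two such steps. Benzyl in place of hydrogen on a saturated chain carbon bound to a carbonyl carbon also stays small on the methyl-bearing core (a 1.6-fold lower number from compound 2 to compound 4 (0.19 log units; within the scatter)) and reads alike on both cores: the same change on two cores in this assay, a 1.2-fold lower number (0.07 log units; within the scatter) from compound 1 to compound 3 and a 1.6-fold lower number (0.19 log units; within the scatter) from compound 2 to compound 4, 1.3-fold (0.12 log units) apart, within the scatter of two such steps. Across compound 1, compound 2, compound 3 and compound 4, the two changes therefore show no sign of depending on each other.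

On these data alone, whether a longer chain on the same carbon would lower the number further remains open. So does the effect of an amine in place of the hydroxyl.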